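The source may hold more compounds than are shown below. What is called first, only, known or untested is meant among the compounds shown, and "the series" means these compounds.

Working notes on the series.

The series is measured in an ADME assay on a cell-free system (plasma, Mus musculus) for metabolic stability; a lower number here means that the compound disappears faster, a higher number that the compound lasts longer. Compound 1, `CC(=O)N1c2ccc(-c3ccc(S(C)(=O)=O)cc3)cc2N(C(=O)C2CC2)C[C@@H]1C`, is the reference point here. In this assay compound 1 gives only a limit of the measurement, > 0.4 h, and not a number. Compound 2, `CC(=O)N1c2ccc(-c3cnn(C4CNC4)c3)cc2N(C(=O)C2CC2)C[C@@H]1C`, also returns only a limit in this assay, > 0.4 h. Among the compounds with values here, compound 3, `COC(=O)N1c2ccc(-c3ccc(S(C)(=O)=O)cc3)cc2N(C(=O)c2ccco2)C[C@@H]1C`, is the one member with a numerical half-life, giving 0.367 h in this assay. The picture is therefore flat: all three values cluster at or close to the limit of > 0.4 h in this assay, at which 2 of the 3 values shown sit, and compound 1 cannot be placed above or below compound 2 or compound 3 on what is shown.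

Compound 4, `CC(=O)N1c2ccc(-c3ccc(S(C)(=O)=O)cc3)cc2N(C(=O)OC(C)C)C[C@@H]1C`, has not been measured. It differs from compound 1 by isopropoxy in place of cyclopropyl on a carbonyl carbon. Within the data shown here, no measured pair of neighbours shows the effect of such a change in this assay, so the expectation rests on the narrow spread of the three values. The step from compound 1 to compound 4 is expected to be a step that the limit leaves unreadable from compound 1 to compound 4, that is, no change beyond the scatter. For compound 4 a half-life of 0.5 h is estimated in this assay, with a range from 0.2 h to 1.2 h.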

Compound 4, half-life: 0.1 h
Compound 4: the middle estimate sits 5.0-fold (0.70 log units) above what was measured; measured number below the stated range.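

In this assay, isopropoxy in place of cyclopropyl on a carbonyl carbon, whose other neighbours are amide-type nitrogen in a ring, gives an at least 4.0-fold lower number from compound 1 to compound 4 (0.60 log units; beyond the scatter), so the compound disappears faster with the isopropoxycarbonyl group than with the cyclopropylcarbonyl group. Within the data shown here, this is the first pair of neighbours, and it shows that this position is not silent in this assay, which the earlier compounds, with no one-place step among them, could not show. The size of the step is only a lower bound, because the starting compound stands at a limit and not at a number: the limit of > 0.4 h in this assay, at which 2 of the 4 values shown sit.

The change swaps a ring for an open chain and adds an oxygen at the same time, so the compounds shown do not tell these two apart; an isopropyl group, which has the open chain without the oxygen, and a cyclopropoxy group, which has the ring with the oxygen, would separate them. As far as these compounds go, whether the same change gives a similar step with a different group elsewhere on the shared core also stays open.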